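Compound 3 to compound 4: fluoro in place of methyl

The source may report more compounds than this note shows. Statements on the series, on what has been measured and on what is new or still open speak of the compounds shown alone.

The series starts from compound 1 `COc1cc(C(=O)c2cn(-c3ccc(C)cc3)cc2-c2ccccc2F)cc(OC)c1OC`, which gives 44 nM in a functional assay on MCF7 cells (Homo sapiens) for cytotoxicity, read by MTT assay, with a stated time of 96 h; a higher number here means a weaker inhibitor, a lower number a stronger inhibitor. Compound 2 `COc1cc(C(=O)c2cn(-c3ccc(C)cc3)cc2-c2ccccc2Cl)cc(OC)c1OC` gives 180 nM, and compound 3 `COc1cc(C(=O)c2cn(-c3ccc(C)cc3)cc2-c2ccc([N+](=O)[O-])cc2)cc(OC)c1OC` gives 200 nM. Compound 3 lies within the scatter of its nearest neighbour, as a 1.1-fold higher number from compound 2 to compound 3 (0.05 log units; within the scatter) shows. Its gap to the furthest value is larger: a 4.5-fold higher number from compound 1 to compound 3 (0.66 log units; beyond the scatter).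

Compound 4 `COc1cc(C(=O)c2cn(-c3ccc(F)cc3)cc2-c2ccc([N+](=O)[O-])cc2)cc(OC)c1OC` keeps the 4-nitrophenyl group of compound 3 and changes one other place: 4-methylphenyl to 4-fluorophenyl, fluoro in place of methyl on an aromatic carbon, para to a large group (fluoro in place of methyl on an aromatic carbon).

Among the compounds with values here, no measured step changes this place, so the series offers no direct measure of the swap. The nearest parallel is the halogen exchange in a 4.1-fold higher number from compound 1 to compound 2 (0.61 log units; beyond the scatter), but that sits on the 2-fluorophenyl group, and it serves only as a rough guide to how far a single-atom change can move the number here. With compound 3 at 200 nM as the anchor, no step beyond the scatter is expected, and no direction is favoured. The expected change is a 1.1-fold lower number from compound 3 to compound 4 (0.05 log units; within the scatter). For compound 4 the estimated value is 180 nM, with an expected range from 70 nM to 450 nM.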

Compound 4, half-maximal inhibitory concentration: 240 nM
Beside the measured number, compound 4's estimate is 1.3-fold (0.12 log units) below it; the range from low to high includes it.
By their numbers in this assay, from the lowest: compound 1; then compounds 2, 3 and 4 (each within the scatter of the next).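

In this assay, within the data shown here, the position on the 4-methylphenyl group is probed directly for the first time, and fluoro in place of methyl gives a 1.2-fold higher number from compound 3 to compound 4 (0.08 log units; within the scatter), so compound 3 and compound 4 cannot be told apart. The earlier steps shown here all lay on the other aryl group, where a 4.1-fold higher number from compound 1 to compound 2 (0.61 log units; beyond the scatter) exceeds the scatter; at this para position, with the 4-nitrophenyl group held fixed, replacing one heavy atom with another produces no step beyond the scatter, although this rests on a single pair. Nothing measured here explains this result.

The compounds shown leave open whether the 4-fluorophenyl group would read the same with the 2-fluorophenyl group of compound 1 kept in place, where compound 1 gives 44 nM. They also leave open whether an amine, a carboxylic acid or a longer alkyl chain at this place on the ring would move the number beyond the scatter.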